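A few compounds are considered here, and "the series" means these few. Any claim that something is new, unique, unknown or untested is made for them only; others in the source may bear on it.

Working notes on the series. Compound 3 `CCCOc1ccc(C(=O)/C=C/c2ccc(C(=O)Nc3cccc(-c4cc(C(=O)OC)no4)c3)cc2)cc1` is known in an ADME assay on Vero cells (Chlorocebus sabaeus) for cytotoxicity, read by MTT assay, with a stated time of 72 h (a lower number here means that less compound is tolerated, a higher number that more compound is tolerated), only as a limit, > 40 ug/mL. Compound 1 `CCOc1ccc(C(=O)/C=C/c2ccc(C(=O)Nc3cccc(-c4cc(C(=O)OC)no4)c3)cc2)cc1` also gives a limit in this assay, > 40 ug/mL. Compound 2 `COC(=O)c1cc(-c2cccc(NC(=O)c3ccc(/C=C/C(=O)c4ccc(C)c([N+](=O)[O-])c4)cc3)c2)on1` gives a limit in this assay, > 80 ug/mL. Compound 4 `COC(=O)c1cc(-c2cccc(NC(=O)c3ccc(/C=C/C(=O)c4cc(OC)c(OC)c(OC)c4)cc3)c2)on1` is not yet measured; it differs from compound 3 as 3,4,5-trimethoxyphenyl in place of 4-propoxyphenyl on a carbonyl carbon. The measured step that bears on this change is the exchange of the aryl group on the same carbonyl carbon, a step that the two limits leave unreadable from compound 2 to compound 3; the chain extension a step that the two limits leave unreadable from compound 1 to compound 3 is also unreadable. All three values sit at limits (the limit of > 40 ug/mL in this assay, at which 2 of the 3 values shown sit; (the limit of > 80 ug/mL in this assay, at which 1 of the 3 values shown sits)), so no size can be read. A step that the limit leaves unreadable from compound 3 to compound 4 is expected, with a limit likely again. Compound 4 is therefore estimated at 60 ug/mL, range 30 ug/mL to 120 ug/mL.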

Compound 4, half-maximal cytotoxic concentration: > 50 ug/mL
Compound 4: no number, only a limit; the forecaster's own chance of this, stated with the estimate: 80%; the middle value lies beyond the limit too.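

In this assay, compound 4 gives only a limit, as do compound 1, compound 2 and compound 3, so no step among these four compounds can be read. The compounds shown leave open the actual half-maximal cytotoxic concentration of each, and so how the aryl group on the carbonyl carbon bears on it.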